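The source may hold more compounds than are shown below. What is called first, only, known or untested is meant among the compounds shown, and "the series" means these compounds.

Measured in a functional assay for inhibition, with Cavia porcellus as the target; on this read-out higher numbers stand for weaker inhibition and lower numbers for stronger inhibition:
Compound 1 `N=C(N)c1ccc(C(=O)NCC(=O)N2CCN(CC(=O)O)C(=O)[C@@H]2CNC(=O)c2ccc(C(=N)N)cc2)cc1` gives 120 nM.
Compound 2 `N=C(N)c1ccc(C(=O)NCC[C@H]2C(=O)N(CC(=O)O)CCN2C(=O)CNC(=O)c2ccc(C(=N)N)cc2)cc1` gives 190 nM.
Compound 3 `N=C(N)c1ccc(C(=O)NCCCC[C@H]2C(=O)N(CC(=O)O)CCN2C(=O)CNC(=O)c2ccc(C(=N)N)cc2)cc1` gives 150 nM.

Compound 2 has the highest number of the three, yet its gaps to compound 3 and to compound 1 both lie within the scatter, so on these numbers the three compounds cannot be separated. Compound 4 `N=C(N)Nc1ccc(C(=O)NCC[C@H]2C(=O)N(CC(=O)O)CCN2C(=O)CNC(=O)c2ccc(C(=N)N)cc2)cc1` differs from compound 2 by one change: a group of 4 heavy atoms (1 carbon, 3 nitrogen; no ring) in place of a group of 3 heavy atoms (1 carbon, 2 nitrogen; no ring), on an aromatic carbon. Going by the values given here, no measured pair shows this change, so its size has to be guessed. In this assay a modest weakening is expected, with a step from compound 2 to compound 4 of about a 2.1-fold higher number from compound 2 to compound 4 (0.32 log units; beyond the scatter). Compound 4 is therefore estimated at 400 nM, with a range from 150 nM to 1200 nM.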

Compound 4, half-maximal inhibitory concentration: 37 nM
For compound 4 the middle estimate is 11-fold (1.03 log units) above the measured one; measured number outside the range, below it.
By their numbers in this assay, from the lowest: compound 4; then compounds 1, 3 and 2 (each within the scatter of the next).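

In this assay, going by these compounds alone, the earlier compounds held no pair differing in one place, so this is the first direct reading of a change on this aromatic carbon, para to a large group. Putting the group of 4 heavy atoms in place of the group of 3 heavy atoms gives a 5.1-fold lower number from compound 2 to compound 4 (0.71 log units; beyond the scatter), showing that the number responds to this swap. No accompanying measurement explains the step. On these data alone, whether a primary amine or a carboxylic acid on this carbon would give a lower or higher number stays open, as does the same swap on the other benzene ring.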